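Tetrazole in Place of Thiadiazole on a Hydrazone Chain

The source may report more compounds than this note shows. Statements on the series, on what has been measured and on what is new or still open speak of the compounds shown alone.

Compound 1 `Cn1nnnc1SCC(=O)N/N=c1/scc(-c2ccccc2)n1-c1ccccc1` gives 67.7 ug/mL in a functional assay on C6 cells (Rattus norvegicus) for cytotoxicity, read by MTT assay, with a stated time of 24 h; on this read-out lower numbers stand for stronger inhibition and higher numbers for weaker inhibition.
Compound 3 `Cc1nnc(SCC(=O)N/N=c2/scc(-c3ccc(F)cc3)n2-c2ccccc2)s1` gives 27.3 ug/mL in this assay.
Compound 2 `Cc1nnc(SCC(=O)N/N=c2/scc(-c3ccc([N+](=O)[O-])cc3)n2-c2ccccc2)s1` gives "not determined" (no result reported) in this assay.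

Compound 2 therefore stands on no single number in this assay, and its place among the others is open. Compound 4 `Cn1nnnc1SCC(=O)N/N=c1/scc(-c2ccc([N+](=O)[O-])cc2)n1-c1ccccc1` differs from it by 1-methyl-1H-tetrazol-5-yl in place of 5-methyl-1,3,4-thiadiazol-2-yl on a sulfur. Among the compounds with values here, no pair of measured compounds carries this single change, so no direction can be read from the data; the change from compound 2 to compound 4 in this assay is expected to stay within the usual scatter. Compound 1 and compound 3, which carry the two side chains with other ring partners, show different numbers. Compound 4 is expected to give 50 ug/mL, in a range from 20 ug/mL to 120 ug/mL.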

Compound 4, half-maximal inhibitory concentration: > 200 ug/mL
Compound 4: a limit, no number (the forecaster's own chance of this, stated with the estimate: 15%); at least 4.0-fold (0.60 log units) between middle value and limit.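

Compound 4 stands at a limit, not a number, in this assay: the limit of > 200 ug/mL in this assay, at which 1 of the 4 values shown sits.

Within the data shown here, this gives the first comparison here that differs in one place: with the 1-methyl-1H-tetrazol-5-yl group kept on the sulfur, nitro in place of hydrogen on an aromatic carbon goes with an at least 2.9-fold higher number from compound 1 to compound 4 (0.47 log units; beyond the scatter), which on this read-out means weaker inhibition.

The exchange of 5-methyl-1,3,4-thiadiazol-2-yl for 1-methyl-1H-tetrazol-5-yl still cannot be read, since compound 2 has no number to set against compound 4. Going by these compounds, whether an amine in place of the nitro would shift the number the same way remains open.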